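The source may report more compounds than this note shows. Statements on the series, on what has been measured and on what is new or still open speak of the compounds shown alone.

In an ADME assay on CHO cells (Cricetulus griseus) for cytotoxicity, read by MTT assay, with a stated time of 24 h (on this read-out higher numbers stand for lower toxicity in this test and lower numbers for higher toxicity in this test), compound 1 (`CC1Cn2c(nc([N+](=O)[O-])c2-c2ccc(CO)cc2)O1`) gives > 500000 nM as a limit of the assay and not as a number. Compound 2 (`Cc1ccc(-c2c([N+](=O)[O-])nc3n2CC(C)O3)cc1`) gives > 250000 nM as a limit too. Compound 3 (`CCCOc1ccc(-c2c([N+](=O)[O-])nc3n2CC(C)O3)cc1`), not yet measured, differs from compound 1 by propoxy in place of hydroxymethyl on an aromatic carbon, para to a large group (propoxy in place of hydroxymethyl on an aromatic carbon). Among the compounds with values here, the one measured step that bears on this change is a step that the two limits leave unreadable from compound 1 to compound 2 and it offers no size to carry over, though it too removes the hydroxy group. In this assay only a modest move toward a lower number is expected because compound 2 gives > 250000 nM as a limit. The expected change is an at least 2.5-fold lower number from compound 1 to compound 3 (0.39 log units; beyond the scatter) as an estimate. For compound 3 the estimate is 200000 nM with an expected range from 60000 nM to 500000 nM and a fair chance of a limit instead of a number.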

Compound 3, half-maximal cytotoxic concentration: > 125000 nM
Compound 3: a limit, no number; the forecaster's own chance of this, stated with the estimate: 65%; the middle value does not contradict the limit.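

The values of compound 1, compound 2 and compound 3 in this assay are all limits and not numbers, and no step among these compounds can be read. The compounds shown leave open whether hydroxymethyl, methyl and propoxy differ at all in this assay.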